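Adding a Methanesulfonamido Group to a Strong Antagonist

The source may report more compounds than this note shows. Statements on the series, on what has been measured and on what is new or still open speak of the compounds shown alone.

Compound 1 `Cc1cccnc1-c1ccc(C(=O)Nc2ccc(Cl)cc2)cc1` and compound 2 `CC(C)(C)c1ccc(NC(=O)c2ccc(-c3ccccn3)cc2)cc1` share a common core and differ in their outer groups. In a functional assay for antagonist activity at transient receptor potential cation channel subfamily V member 1 (Rattus norvegicus) (a higher number here means a weaker inhibitor, a lower number a stronger inhibitor), compound 1 gives 2020 nM. In this assay compound 2 gives 8 nM. Of the two numbers on hand, compound 2 has the lowest, and the gap to compound 1 lies well beyond the scatter of this assay. Compound 3 `CC(C)(C)c1ccc(NC(=O)c2ccc(-c3ncccc3NS(C)(=O)=O)cc2)cc1` has not yet been measured. It differs from compound 2 in one place: methanesulfonamido in place of hydrogen on an aromatic carbon of a six-membered aromatic ring with one nitrogen, ortho to a large group and two atoms from the ring nitrogen. For the measured compounds named here, no pair of measured compounds shows a change of this kind, so there is no measured step to lean on. The expected step of a 2.5-fold higher number from compound 2 to compound 3 (0.40 log units; beyond the scatter) in this assay is modest, more likely toward a higher number than a lower one, and may well stay within the scatter. Compound 3 is estimated at 20 nM in this assay, with a range from 5 nM to 80 nM.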

Compound 3, half-maximal inhibitory concentration: 35 nM
Beside the measured number, compound 3's estimate is 1.8-fold (0.24 log units) below it; low and high end bracket the measured number.
By their numbers in this assay, from the lowest: compound 2; then compound 3; then compound 1.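

Placing methanesulfonamido on this aromatic carbon, ortho to a large group and two atoms from the ring nitrogen, gives a 4.4-fold higher number from compound 2 to compound 3 (0.64 log units; beyond the scatter) in this assay, the first measured change at this position. The step lies beyond the scatter, so the position is not indifferent to this change, yet the step is modest, and with 5 heavy atoms added, compound 3 still gives 35 nM in this assay. The compounds shown offer no measurement of any property that could account for the step.

As far as these compounds go, whether the rise follows from the size of the entering group or from its particular atoms stays open, since a single substituent at this place cannot separate the two; an amine, a methyl group or a fluorine atom on the same carbon would each test this differently. From the compounds shown here alone, it is also open whether the hydrogen on the sulfonamide nitrogen matters, as an N-methyl methanesulfonamido group would show, and whether the same step would appear with a chlorine atom in place of the tert-butyl group on the anilide ring.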